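Hydroxy to Acetamido on the Triazole Aryl Ring

The source may hold more compounds than are shown below. What is called first, only, known or untested is meant among the compounds shown, and "the series" means these compounds.

Compound 1 `C#CCO/N=C1/C[C@@H](c2ccc(OC)cc2)Oc2cc(OC)c(CC=C(C)C)cc21`: 41%
Compound 2 `COc1ccc([C@@H]2C/C(=N/OCc3cn(-c4ccc(O)cc4)nn3)c3cc(CC=C(C)C)c(OC)cc3O2)cc1`: 64%

Of the compounds shown here, two sharing one core have been measured in a functional assay on PC-3 cells (Homo sapiens) for inhibition, read by sulforhodamine B assay, with a stated time of 48 h, tested at 50 uM; a higher number here means more inhibition of growth at the concentration tested, a lower number less inhibition of growth. Compound 1 gives 41%, and compound 2 gives 64%. Within the data shown here, the single measured step, a number 23 percentage points higher from compound 1 to compound 2 (beyond the scatter), replaces ethynyl on a saturated chain carbon bound to an oxygen on an unsaturated carbon with 1-(4-hydroxyphenyl)-1H-1,2,3-triazol-4-yl. Compound 2 therefore stands highest of the two numbers, with compound 1 the nearest, a number lower beyond the scatter.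

Compound 3 `COc1ccc([C@@H]2C/C(=N/OCc3cn(-c4ccc(NC(C)=O)cc4)nn3)c3cc(CC=C(C)C)c(OC)cc3O2)cc1` has not yet been measured. It differs from compound 2 by acetamido in place of hydroxy on an aromatic carbon, placed on an aromatic carbon of a six-membered aromatic ring of carbon only, para to a large group. Among the measured compounds shown here, no measured step changes this group; the only step known, from ethynyl to the triazolyl aryl, concerns a different part of the molecule and gives no guide to a swap of hydroxy for acetamido. In this assay compound 3 is therefore expected to stay close to compound 2, with a step of about a number 4 percentage points lower from compound 2 to compound 3 (within the scatter), not beyond the scatter. The estimate for compound 3 is 60%, between 40% and 78%.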

Compound 3, percent growth inhibition at one concentration: 2%
The estimate for compound 3 lay 58 percentage points above the measured number, outside the stated range (below it).
By their numbers in this assay, from the lowest: compound 3; then compound 1; then compound 2.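

In this assay the exchange of hydroxy for acetamido gives a number 62 percentage points lower from compound 2 to compound 3 (beyond the scatter) and is the larger of the two steps known in this series. Among these compounds, the earlier step, a number 23 percentage points higher from compound 1 to compound 2 (beyond the scatter), showed only what the triazolyl aryl unit does in place of ethynyl, whereas this one shows that the result also depends strongly on the single group on the aromatic carbon, para to a large group. Hydroxy and acetamido each count one hydrogen-bond donor and one hydrogen-bond acceptor, so this equal count does not keep the number up, and compound 3 retains only 2% of inhibition in a change that leaves the rest of the molecule untouched.

Nothing available explains this loss. The compounds shown leave open whether compound 2 owes its number to the hydroxy itself or whether compound 3 loses out to the acetamido in particular, a question that an amine, a methoxy or a carboxylic acid on the same aromatic carbon would help to separate.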